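A few compounds are considered here, and "the series" means these few. Any claim that something is new, unique, unknown or untested is made for them only; others in the source may bear on it.

Measured compounds:
- compound 1 `O=C(/C=C/c1cccc(NC(=O)c2ccccc2Cl)c1)c1nc2ccccc2[nH]1`: 1280 nM
- compound 2 `O=C(/C=C/c1cccc(NS(=O)(=O)c2cccc(Cl)c2)c1)c1nc2ccccc2[nH]1`: 737 nM

In a functional assay on HCT-116 cells (Homo sapiens) for antiproliferative activity, read by MTT assay, with a stated time of 48 h (on this read-out higher numbers stand for weaker inhibition and lower numbers for stronger inhibition), compound 1 gives the highest number of the two measured compounds, with compound 2 as its nearest neighbour at 737 nM; the step of a 1.7-fold lower number from compound 1 to compound 2 (0.24 log units; within the scatter) lies within the scatter, so the two values cannot be ordered.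

Compound 3 `Cc1cccc(S(=O)(=O)Nc2cccc(/C=C/C(=O)c3nc4ccccc4[nH]3)c2)c1` has not yet been measured in this assay. It differs from compound 1 at one place: (3-methylphenyl)sulfonyl in place of (2-chlorophenyl)carbonyl on a nitrogen on an aromatic ring. Within the data shown here, the only measured step that bears on this change is the one in which (3-chlorophenyl)sulfonyl replaces (2-chlorophenyl)carbonyl on the same nitrogen, a 1.7-fold lower number from compound 1 to compound 2 (0.24 log units; within the scatter). Compound 3 carries a (3-methylphenyl)sulfonyl at that nitrogen, so the same kind of exchange of carbonyl for sulfonyl applies, and the measured step was within the scatter. No step beyond the scatter is therefore expected in this assay from compound 1 to compound 3, and if anything a number close to that of compound 2 is expected. Compound 3 is accordingly estimated at 850 nM, with a range from 300 nM to 2500 nM. This estimate corresponds to an expected step of a 1.5-fold lower number from compound 1 to compound 3 (0.18 log units; within the scatter).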

Compound 3, half-maximal inhibitory concentration: 597 nM
For compound 3 the middle estimate is 1.4-fold (0.15 log units) above the measured one; measured number inside the range.
By their numbers in this assay, from the lowest: compounds 3, 2 and 1 (each within the scatter of the next, the first and the last beyond it).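

In this assay, the exchange at the nitrogen on the aromatic ring now gives a 2.1-fold lower number from compound 1 to compound 3 (0.33 log units; beyond the scatter), the first step of this kind among these compounds to clear the scatter, though only modestly. The second step, a 1.2-fold lower number from compound 2 to compound 3 (0.09 log units; within the scatter), stays within the scatter, so methyl in place of chloro on an aromatic carbon of the arylsulfonyl group does not separate these two compounds, and they cannot be ordered. Thus, the two sulfonyl compounds sit together, yet only compound 3 is distinguished from compound 1, and nothing available accounts for this result.

The step from compound 1 to compound 3 changes the carbonyl to a sulfonyl and also replaces the 2-chlorophenyl with a 3-methylphenyl, so the compounds shown do not tell how much of it belongs to either change. On these data alone, it also remains open whether a methoxy, an amine or a carboxylic acid on that phenyl ring, or a simple alkyl chain on the sulfonyl in place of the ring, would give a number near those of compound 2 and compound 3.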